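From pyridin-4-yl to pyridin-3-yl on the amide

The source may report more compounds than this note shows. Statements on the series, on what has been measured and on what is new or still open speak of the compounds shown alone.

Compound 1 `CN(C)Cc1csc(NC(=O)c2cc(C(C)(C)C)nn2Cc2ccccc2)n1`: 2.6
Compound 2 `CC(C)(C)c1cc(C(=O)Nc2ccccc2)n(Cc2ccccc2)n1`: 4.7
Compound 3 `CC(C)(C)c1cc(C(=O)Nc2ccncc2)n(Cc2ccccc2)n1`: 2.6

Of the compounds shown here, three have been measured in a physicochemical assay for lipophilicity, read by HPLC, at pH 3.0 (on this read-out lower numbers stand for lower lipophilicity and higher numbers for higher lipophilicity), so far, and two of them share the lowest number. The data show no change at the digits printed from compound 1 to compound 3 (within the scatter) for that pair. The widest gap to this low pair is a number 2.10 log units lower from compound 2 to compound 3 (beyond the scatter) and is matched by a number 2.10 log units higher from compound 1 to compound 2 (beyond the scatter) on the other side.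

The next structure, compound 4 `CC(C)(C)c1cc(C(=O)Nc2cccnc2)n(Cc2ccccc2)n1`, has pyridin-3-yl in place of pyridin-4-yl on an amide-type nitrogen. Going by the values given here, no measured step exchanges these two groups. The nearest evidence is the large step from phenyl to pyridin-4-yl, and compound 4 has no phenyl at that place, so a return to the level of compound 2 (4.7) is not expected. A modest upward move is expected instead (a number 0.40 log units higher from compound 3 to compound 4 (beyond the scatter)), though it may not clear the scatter. Compound 4 is estimated at 3 (expected range 2.5 to 3.6).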

Compound 4, distribution coefficient: 3.5
Compound 4: middle estimate off by 0.50 log units, on the low side; the range from low to high includes it.
By their numbers in this assay, from the lowest: compounds 1 and 3 (each within the scatter of the next); then compound 4; then compound 2.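

In this assay, the two groups have the same atoms and the same counts, yet the exchange of pyridin-4-yl for pyridin-3-yl on the amide-type nitrogen gives a real step (a number 0.90 log units higher from compound 3 to compound 4 (beyond the scatter)), so the attached isomer matters at this place and not only the atom count. Compound 4 also stays apart from the phenyl compound (a number 1.20 log units lower from compound 2 to compound 4 (beyond the scatter)) and from the 4-((dimethylamino)methyl)-1,3-thiazol-2-yl compound (a number 0.90 log units higher from compound 1 to compound 4 (beyond the scatter)), which places it between them rather than level with either. Nothing available here accounts for the gap between the two isomers.

Where pyridin-2-yl on the same amide-type nitrogen would fall in this assay stays open, as does whether an added amino or methyl group on the pyridin-3-yl ring would hold the level of compound 4. Whether the same exchange gives a step of like size on a different core is also unanswered.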